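This account rests on a few compounds, and the source may have more. Where it says the series, first, only, none or still open, it means among the compounds named here.

The three measured compounds were all tested in a functional assay on the whole organism for inhibition, with Canis familiaris (Canis lupus familiaris) as the target; on this read-out lower numbers stand for an effect already at smaller amounts and higher numbers for an effect only at larger amounts of compound.

Compound 1 `CCN1CCCC1CNC(=O)c1cc(N(C)S(=O)(=O)N(C)C)ccc1OC` gives 1 mg/kg in this assay.
Compound 2 `CCN1CCCC1CNC(=O)c1cc(N(C)S(=O)(=O)N(C)C)c(C)cc1OC` gives 1 mg/kg in this assay.
Compound 3 `CCN1CCCC1CNC(=O)c1cc(NS(=O)(=O)NC)ccc1OC` gives in this assay only a limit of the assay, > 1 mg/kg.

All three share the same core, an amide joined to an aromatic ring that carries a methoxy group, and they differ in the group on that ring and in one methyl group. From compound 1 to compound 2 the change is methyl in place of hydrogen on an aromatic carbon. The step that it made is no change at the digits printed from compound 1 to compound 2 (within the scatter). Going by these compounds, from compound 1 to compound 3 the change is (methylsulfamoyl)amino in place of (dimethylsulfamoyl)(methyl)amino on an aromatic carbon, and the step is a number no lower from compound 1 to compound 3 (the limit leaves the size open); the value of compound 3 is a limit (the limit of > 1 mg/kg in this assay, at which 1 of the 3 values shown sits), so the size of that step stays open.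

Compound 4 `CCN1CCCC1CNC(=O)c1cc(NS(=O)(=O)NC)c(C)cc1OC` has not yet been measured in this assay. It differs from compound 3 by methyl in place of hydrogen on an aromatic carbon. Among the compounds with values here, this is the same kind of change as the one from compound 1 to compound 2, but the surroundings differ: in compound 2 the methyl is ortho to a (dimethylsulfamoyl)(methyl)amino group, in compound 4 it is ortho to a (methylsulfamoyl)amino group. Because no change at the digits printed from compound 1 to compound 2 (within the scatter) stayed within the scatter, the expected step is a step that the limit leaves unreadable from compound 3 to compound 4. Since compound 3 gave only a limit, compound 4 is also expected to be reported at or beyond that limit. The estimate for compound 4 in this assay is 2 mg/kg, expected to fall between 1 mg/kg and 6 mg/kg.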

Compound 4, dose for half-maximal effect: > 1 mg/kg
Compound 4: a limit, no number; the forecaster's own chance of this, stated with the estimate: 70%; the middle value lies beyond the limit too.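

In this assay compound 4 gives > 1 mg/kg, which is a limit of the assay and not a number. Putting (methylsulfamoyl)amino in place of (dimethylsulfamoyl)(methyl)amino has now been seen on two cores, and on the second the step is a number no lower from compound 2 to compound 4 (the limit leaves the size open), so the direction seen on the first core is not contradicted on the second, but the comparison of sizes stops there: the same change on two cores in this assay, a number no lower (the limit leaves the size open) from compound 1 to compound 3 and a number no lower (the limit leaves the size open) from compound 2 to compound 4; the limit leaves it open whether they differ. The sizes of the new steps to compound 4 cannot be read, so it remains unknown whether this swap costs the same on both cores, or whether the methyl on the aromatic carbon changes anything when the (methylsulfamoyl)amino group is present, as the values reach only this far: the limit of > 1 mg/kg in this assay, at which 2 of the 4 values shown sit.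

The compounds shown leave open how far compound 3 and compound 4 lie past the limit, and so how much of the effect is lost with the (methylsulfamoyl)amino group. They also leave open what other groups would do at the same place on the ring, such as a chlorine atom or an ethyl chain in place of the methyl, or a simple amine in place of the sulfamoyl group.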